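Ethyl Carbamate Replaces Trifluoromethyl on the Shared Core

The compounds below may be only part of what the source reports. "The series", "measured", "known", "first", "only" and "open" are said of these compounds alone.

Compound 1 `Nc1cccc(CNc2cc(Br)cc3[nH]ncc23)c1`: 31%
Compound 2 `ONc1cccc(CNc2cc(Br)cc3[nH]ncc23)c1`: 53%
Compound 3 `FC(F)(F)c1cccc(CNc2cc(Br)cc3[nH]ncc23)c1`: 16%

In an assay for inhibition of Indoleamine 2,3-dioxygenase 1 (Homo sapiens), with a stated time of 1 h, tested at 10 uM (on this read-out lower numbers stand for less inhibition and higher numbers for more inhibition at the one concentration tested (going by the name of the read-out)), compound 3 gives the lowest of the three numbers, with compound 1 nearest and compound 2 furthest from it. The step to compound 4 `CCOC(=O)Nc1cccc(CNc2cc(Br)cc3[nH]ncc23)c1` is (ethoxycarbonyl)amino in place of trifluoromethyl on an aromatic carbon. For the measured compounds named here, two measured steps bear on it, both beyond the scatter: a number 15 percentage points lower from compound 1 to compound 3 (beyond the scatter) and a number 37 percentage points lower from compound 2 to compound 3 (beyond the scatter). In both the trifluoromethyl group replaces a nitrogen-bearing group with a hydrogen-bond donor, and in both the number falls; the reverse move here brings back such a group, though one that differs from amino and hydroxyamino. A modest rise is therefore expected: a number 14 percentage points higher from compound 3 to compound 4 (beyond the scatter). Compound 4 is estimated at 30%, within a range from 12% to 50%.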

Compound 4, a percentage reported as inhibition, at one concentration (the size of the read-out at that concentration, not a potency): 29%
Beside the measured number, compound 4's estimate is 1 percentage points above it; low and high end bracket the measured number.
By their numbers in this assay, from the lowest: compound 3; then compounds 4 and 1 (each within the scatter of the next); then compound 2.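

In this assay, ethoxycarbonyl on the nitrogen gives a number 2 percentage points lower from compound 1 to compound 4 (within the scatter), so at this aromatic carbon the (ethoxycarbonyl)amino group reads level with amino, and a number 13 percentage points higher from compound 3 to compound 4 (beyond the scatter) shows that it regains ground lost with trifluoromethyl. The step of a number 24 percentage points lower from compound 2 to compound 4 (beyond the scatter) shows that a group on this nitrogen does not by itself carry the gain seen with hydroxy. Nothing available explains these differences. Still open, on these data alone, is whether an acetamide or a urea on this nitrogen would read nearer to compound 2 or to compound 1, and whether a longer chain on the carbamate oxygen would shift the number.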